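This account rests on a few compounds, and the source may have more. Where it says the series, first, only, none or still open, it means among the compounds named here.

Compound 1 `O=C(O)COc1ccc(NC(=O)COc2ccccc2)cc1F` has no number in a functional assay on CHO cells for agonist activity at Free fatty acid receptor 1 (Homo sapiens), read by FLIPR; on this read-out lower numbers stand for an effect already at smaller amounts and higher numbers for an effect only at larger amounts of compound; for compound 1 the record in this assay reads "not determined" (no result reported). The same holds for compound 2 `CCOc1ccccc1OC(C)C(=O)Nc1ccc(OCC(=O)O)c(F)c1`, whose entry in this assay is "not determined" (no result reported). Only compound 3 `CC(Oc1ccccc1F)C(=O)Nc1ccc(OCC(=O)O)c(F)c1` carries a value: in this assay compound 3 gives 136 nM. Going by the values given here, compound 1 therefore cannot be placed against any measured neighbour, and no step from it has been measured.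

Compound 4 `COc1cccc(OCC(=O)Nc2ccc(OCC(=O)O)c(F)c2)c1` differs from compound 1 by methoxy in place of hydrogen on an aromatic carbon. Among the compounds with values here, with no measured value for compound 1, the size of this step cannot be read from the data; the only anchor is compound 3, which shares the core and the acid-bearing fragment and gives 136 nM in this assay. On that anchor, compound 4 is expected to land in a broadly similar region, with wide uncertainty because nothing shows how the methoxy-bearing fragment compares. Compound 4 is estimated at 350 nM, with a range from 80 nM to 1500 nM.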

Compound 4, half-maximal effective concentration: 148 nM
Compound 4: the middle estimate sits 2.4-fold (0.37 log units) above what was measured; the measured number falls inside the stated range.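

In this assay compound 1 has no single number, so no new step can be read from compound 4. The compounds shown leave open how methoxy in place of hydrogen changes the read-out, and no available evidence bears on this result.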